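Chlorophenoxy dienone series: the step to compound 3

The compounds below may be only part of what the source reports. "The series", "measured", "known", "first", "only" and "open" are said of these compounds alone.

Values measured in a functional assay on PC-3 cells (Homo sapiens) for cytotoxicity, read by MTT assay, with a stated time of 48 h (a lower number here means a stronger inhibitor, a higher number a weaker inhibitor), are as follows
- compound 1 `COc1cc(OC)c(/C=C/C(=O)/C=C/c2cc3ccccc3nc2Cl)c(OC)c1` gives > 10000 nM
- compound 2 `COc1ccc(/C=C/C(=O)/C=C/c2cc3ccccc3nc2Oc2cccc(Cl)c2)cc1OC` gives > 10000 nM

Compound 2 gives only a limit in this assay (> 10000 nM) and no number. Compound 1 also gives only a limit (> 10000 nM) in the same assay. Among the measured compounds shown here, both compounds therefore sit at the limit of > 10000 nM in this assay, at which 2 of the 2 values shown sit, and no measured step exists.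

Compound 3 `COc1cc(OC)c(/C=C/C(=O)/C=C/c2cc3ccccc3nc2Oc2cccc(Cl)c2)c(OC)c1` carries 2,4,6-trimethoxyphenyl in place of 3,4-dimethoxyphenyl on a double-bonded chain carbon bound to a double-bonded chain carbon. Compound 1 already carries 2,4,6-trimethoxyphenyl and shows the limit > 10000 nM in this assay. The expected change a number no higher from compound 2 to compound 3 (the limit leaves the size open) is none beyond the scatter, with neither direction favoured. The estimate for compound 3 is 10000 nM, with an expected range from 2500 nM to 30000 nM.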

Compound 3, half-maximal inhibitory concentration: > 10000 nM
Compound 3 was reported as a limit; the forecaster's own chance of this, stated with the estimate: 60%; the middle value lies on the limit itself.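

Compound 3 gives only a limit in this assay, so neither step from compound 1 or compound 2 to compound 3 can be read: the limit of > 10000 nM in this assay, at which 3 of the 3 values shown sit.

Still open, from the compounds shown here alone, is whether 2,4,6-trimethoxyphenyl in place of 3,4-dimethoxyphenyl, or 3-chlorophenoxy in place of chloro, changes the potency at all.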